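A few compounds are considered here, and "the series" means these few. Any claim that something is new, unique, unknown or untested is made for them only; others in the source may bear on it.

Compound 1 `O=C(Nc1ccc2[nH]ncc2n1)[C@H]1CCCN1C(=O)C1(c2ccc(F)cc2)CCC1` and compound 2 `COc1ccc(C2(C(=O)N3CCC[C@@H]3C(=O)Nc3ccc4[nH]ncc4n3)CCC2)cc1` share one core and differ only at a single position on the outer benzene ring. In an assay on isolated protein for inhibition of histone acetyltransferase p300 (Homo sapiens), with a stated time of 60 min (on this read-out higher numbers stand for weaker inhibition and lower numbers for stronger inhibition), compound 1 gives 0.126 nM, and compound 2 gives 0.251 nM. Among the two numbers measured so far, compound 2 stands at the higher one, but the step of a 2.0-fold higher number from compound 1 to compound 2 (0.30 log units; within the scatter) lies within the scatter, so the two compounds cannot be told apart on this read-out.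

Compound 3 `O=C(Nc1ccc2[nH]ncc2n1)[C@H]1CCCN1C(=O)C1(c2ccc(Cl)cc2)CCC1` has not yet been measured in this assay. It is reached from compound 2 by chloro in place of methoxy on an aromatic carbon. Within the data shown here, the only measured step that bears on this change is the one from compound 1 to compound 2, in which fluoro gave way to methoxy on the same aromatic carbon and the number moved by a 2.0-fold higher number from compound 1 to compound 2 (0.30 log units; within the scatter), a shift no larger than the scatter. Since a halogen now replaces the methoxy, compound 3 is expected to land close to the values of both measured compounds, with a step of a 1.6-fold lower number from compound 2 to compound 3 (0.20 log units; within the scatter) that stays inside the scatter. Compound 3 is therefore estimated at 0.16 nM, with a plausible range from 0.06 nM to 0.45 nM.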

Compound 3, half-maximal inhibitory concentration: 0.1 nM
Compound 3: the middle estimate sits 1.6-fold (0.20 log units) above what was measured; the measured number falls inside the stated range.
By their numbers in this assay, from the lowest: compounds 3, 1 and 2 (each within the scatter of the next, the first and the last beyond it).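

At this position on the outer benzene ring, chloro in place of methoxy gives a 2.5-fold lower number from compound 2 to compound 3 (0.40 log units; beyond the scatter) in this assay and is the only step among these compounds to clear the scatter, though modestly. Chloro in place of fluoro gives a 1.3-fold lower number from compound 1 to compound 3 (0.10 log units; within the scatter) and so leaves these two halogens indistinguishable; the read-out therefore separates methoxy from chloro but not from fluoro, and fluoro stays within the scatter of both. The change from methoxy to chloro replaces two heavy atoms, one of them a hydrogen-bond acceptor, with a single chlorine atom, but no measurement shown explains the step between compound 2 and compound 3.

The compounds shown carry only fluoro, chloro and methoxy on this aromatic carbon, so it remains open how the read-out would respond to an amine, a carboxylic acid or a longer chain in the same place. On these data alone, it also remains open whether the same exchange of methoxy for chloro would give a step of similar size on a different core.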